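The source may report more compounds than this note shows. Statements on the series, on what has been measured and on what is new or still open speak of the compounds shown alone.

Measured so far:
compound 1 `Cc1ccc2c(c1)N(CC(=O)NC(C)(C)C)C(=O)[C@H](NC(=O)Nc1cccc(C(=O)O)c1)C[C@@H]2C1CCCCC1`, in an assay on isolated protein for binding affinity to Cholecystokinin receptor type A (Cavia porcellus) (on this read-out higher numbers stand for weaker inhibition and lower numbers for stronger inhibition), compound 1 gives 1400 nM; 2300 nM (2 entries)
compound 2 `COC(=O)c1cccc(NC(=O)N[C@@H]2C[C@H](C3CCCCC3)c3ccc(C)cc3N(CC(=O)NC(C)(C)C)C2=O)c1`, in this assay compound 2 gives 370 nM

Going by the values given here, compound 2 stands at the only number reported for it; a further entry for it carries no single number. The two values of compound 1 are higher than that of compound 2. Compound 3 `Cc1ccc2c(c1)N(CC(=O)NC(C)(C)C)C(=O)[C@H](NC(=O)Nc1cccc(C(=O)NS(C)(=O)=O)c1)C[C@@H]2C1CCCCC1` differs from compound 2 by methanesulfonamido in place of methoxy on a carbonyl carbon. Among the compounds with values here, no measured pair shows this change, so the step from compound 2 to compound 3 is expected to be a modest loss of a 2.2-fold higher number from compound 2 to compound 3 (0.33 log units; beyond the scatter). Compound 3 is estimated at 800 nM, between 200 nM and 3000 nM.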

Compound 3, half-maximal inhibitory concentration: 520 nM
Compound 3: middle estimate off by 1.5-fold (0.19 log units), on the high side; the range from low to high includes it.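

In this assay, methanesulfonamido in place of methoxy on a carbonyl carbon gives a 1.4-fold higher number from compound 2 to compound 3 (0.15 log units; within the scatter), so this place takes the new group without a change that can be read. Compound 3 gives 520 nM, a number lower than both entries of compound 1, the carboxylic acid of the series: the several entries of compound 1 in this assay, 1400 nM; 2300 nM (2 entries)

The compounds shown leave open how an amine on the same carbonyl carbon would read. They also leave open whether a longer chain or a phenyl ring in place of the methyl on the sulfonyl would hold this level.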